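From compound 1 to compound 4: a larger amide substituent

The source may hold more compounds than are shown below. What is called first, only, known or untested is meant among the compounds shown, and "the series" means these compounds.

Compound 1 `CNC(=O)CC1CCc2cc(OC)c(OC)cc21` was tested in a functional assay on the whole organism (strain Wistar) for inhibition, with Rattus norvegicus as the target, read by paw edema, with stated times of 60 min and 4 h, at a dose of 100 mg/kg by the oral route (on this read-out higher numbers stand for more inhibition at the one dose given (going by the name of the read-out) and lower numbers for less inhibition), where compound 1 gives 29.7%. This is the lowest of the three numbers recorded, though only within the scatter of the other two: compound 2 `COc1cc2c(cc1OC)C(CC(=O)N(C)C)CC2` gives 35.9%, and compound 3 `CCN(CC)C(=O)CC1CCc2cc(OC)c(OC)cc21` gives 37.5%. Both of these differ from compound 1 only in the groups on the amide nitrogen, and the third pairing, a number 1.6 percentage points higher from compound 2 to compound 3 (within the scatter), is likewise within the scatter.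

Compound 4 `COc1cc2c(cc1OC)C(CC(=O)NC1CCCCC1)CC2` has not yet been measured in this assay. It differs from compound 1 in one place: cyclohexyl in place of methyl on an amide-type nitrogen. The measured steps that bear on this change are the two that also alter the amide nitrogen, a number 6.2 percentage points higher from compound 1 to compound 2 (within the scatter) and a number 7.8 percentage points higher from compound 1 to compound 3 (within the scatter); neither moved the read-out beyond the scatter. Within the data shown here, no measured compound carries a ring on the amide nitrogen, so the effect of the cyclohexyl itself is untested. On the evidence at hand, compound 4 is expected to show a step of a number 4.3 percentage points higher from compound 1 to compound 4 (within the scatter) that stays within the scatter. Compound 4 is therefore estimated at 34%, with a range from 20% to 48%.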

Compound 4, a percentage reported as inhibition, in the whole organism at one dose (the size of the read-out at that dose, not a potency): 50%
The estimate for compound 4 lay 16 percentage points below the measured number, and the stated range ends below it.
By their numbers in this assay, from the lowest: compounds 1, 2 and 3 (each within the scatter of the next); then compound 4.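

Among these compounds, until this result, no change on the amide nitrogen of the shared core had moved the read-out in this assay beyond the scatter, and cyclohexyl in place of methyl on this amide-type nitrogen is the first that does (a number 20.3 percentage points higher from compound 1 to compound 4 (beyond the scatter)). The two open-chain tertiary amides also fall short of the cyclohexyl amide by more than the scatter (a number 14.1 percentage points higher from compound 2 to compound 4 (beyond the scatter); a number 12.5 percentage points higher from compound 3 to compound 4 (beyond the scatter)), so the position does respond to its substituent, and among these four compounds the only clear gain comes with the ring, on a nitrogen that keeps the amide hydrogen. Nothing given here explains this gain.

The compounds shown do not separate the ring itself from the number of carbons it brings: an open-chain hexyl, a cyclopentyl or a phenyl on the same nitrogen would speak to that. Nor do they show whether the amide hydrogen matters, which a nitrogen bearing both cyclohexyl and methyl would test, and with a single dose throughout, the numbers give no measure of potency.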